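A few compounds are considered here, and "the series" means these few. Any claim that something is new, unique, unknown or untested is made for them only; others in the source may bear on it.

Compound 1, with the structure `O=C(Nc1ccc(Cl)cc1)C1CCCN(C(=O)c2cccc(-c3nccs3)c2)C1`, is the reference point for this comparison. Within the data shown here, in an ADME assay on PC-3 cells (Homo sapiens) for cytotoxicity, read by WST assay, tested at 100 uM (on this read-out higher numbers stand for more inhibition at the one concentration tested (going by the name of the read-out) and lower numbers for less inhibition), compound 1 gives 32%, the highest reading among the three compounds measured so far. The two others sit well below it, beyond the usual scatter of this kind of measurement: compound 2, with the structure `O=C(Nc1cccc(Cc2ccccc2)c1)C1CCCN(C(=O)c2cccc(-c3ccco3)c2)C1`, gives 0% in this assay, and compound 3, with the structure `O=C(Nc1cccc(Cc2ccccc2)c1)C1CCCN(C(=O)c2cc(C(F)(F)F)cc(C(F)(F)F)c2)C1`, gives 0% in this assay. Both of those carry a different substituent on the amide nitrogen and a different acyl group than compound 1, so neither offers a one-point comparison.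

Compound 4, with the structure `COc1cccc(C(=O)N2CCCC(C(=O)Nc3ccc(Cl)cc3)C2)c1`, keeps the core and the chlorine-bearing aniline of compound 1 and changes only the acyl part, with methoxy in place of 1,3-thiazol-2-yl on an aromatic carbon. Among the measured compounds shown here, no measured pair shows this exact change, so its effect is uncertain; a modest step down, or none beyond the scatter, seems most likely. Compound 4 is expected to give 20% in this assay, between 0% and 42%, a step of a number 12 percentage points lower from compound 1 to compound 4 (beyond the scatter).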

Compound 4, a percentage reported as inhibition, at one concentration (the size of the read-out at that concentration, not a potency): 0%
Compound 4: middle estimate off by 20 percentage points, on the high side; measured number inside the range.
By their numbers in this assay, from the lowest: compounds 2, 3 and 4 (each within the scatter of the next); then compound 1.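

Among these compounds, with the core and the chlorine-bearing aniline held fixed, this is the only comparison so far that changes a single place: methoxy in place of 1,3-thiazol-2-yl on an aromatic carbon, meta to a large group, gives a number 32 percentage points lower from compound 1 to compound 4 (beyond the scatter) in this assay. The reading of compound 1 therefore depends on what sits at this position, and with methoxy there, none of that reading remains beyond the scatter. Nothing available explains why this change has such an effect.

Going by these compounds, it remains open whether a pyridine ring, an ethoxy group or an amine at this position would keep the reading or lose it. Also open, on these data alone, is whether the 1,3-thiazol-2-yl group would have a similar effect with a different group on the amide nitrogen.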